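This account rests on a few compounds, and the source may have more. Where it says the series, first, only, none or still open, it means among the compounds named here.

Compound 3 `CC1=CC[C@H](C(C)(C)NC(=S)N/N=C/c2ccccc2O)CC1` carries a 2-hydroxyphenyl on the carbon with a double bond to nitrogen. In a functional assay on K562 cells (Homo sapiens) for inhibition, read by sulforhodamine B assay, with a stated time of 48 h (on this read-out higher numbers stand for weaker inhibition of growth and lower numbers for stronger inhibition of growth), compound 3 gives 800 nM, the lowest of the two numbers shown. In this assay compound 1 `CC1=CC[C@H](C(C)(C)N=C=S)CC1` gives 4000 nM. Compound 2 `CC1=CC[C@H](C(C)(C)NC(=S)N/N=C/c2ccc(O)cc2)CC1`, bearing a 4-hydroxyphenyl in that place, reaches only the limit of > 100000 nM in this assay. Going by the values given here, the single measured step, an at least 120-fold lower number from compound 2 to compound 3 (2.09 log units; beyond the scatter), exchanges one hydroxyphenyl for the other and keeps the hydroxyl group, so it bears only indirectly on the next change. Compound 4 `CC1=CC[C@H](C(C)(C)NC(=S)N/N=C/c2cccc(Cl)c2)CC1` differs from compound 3 by 3-chlorophenyl in place of 2-hydroxyphenyl on a carbon with a double bond to nitrogen. Among the compounds with values here, no measured pair swaps the hydroxyl for chlorine, so the step in this assay from compound 3 to compound 4 cannot be read from the data. Because compound 1 4000 nM without any aryl group sits well above compound 3, and the two hydroxyphenyl compounds lie far apart, a weakening step is expected. Compound 4 is therefore expected to give 6000 nM, within 1000 nM to 60000 nM, an expected step of a 7.5-fold higher number from compound 3 to compound 4 (0.88 log units; beyond the scatter).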

Compound 4, concentration for 50% growth inhibition: 5400 nM
Estimate against measurement, compound 4: 1.1-fold (0.05 log units) above; the measured number falls inside the stated range.
By their numbers in this assay, from the lowest: compound 3; then compounds 1 and 4 (each within the scatter of the next). At a limit, above all of these: compound 2.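

In this assay, a hydroxyl on the aryl group is not needed for a measurable number at this place: 3-chlorophenyl in place of 4-hydroxyphenyl gives an at least 18-fold lower number from compound 2 to compound 4 (1.26 log units; beyond the scatter). Yet 3-chlorophenyl in place of 2-hydroxyphenyl gives a 6.8-fold higher number from compound 3 to compound 4 (0.83 log units; beyond the scatter), so among the three aryl compounds the 3-chlorophenyl lies between the two hydroxyphenyl groups, and a hydroxyphenyl group marks both ends of the series. The upper end, compound 2, is a limit of the assay and not a number: the limit of > 100000 nM in this assay, at which 1 of the 4 values shown sits.

The hydroxyl and the chlorine sit at different ring positions in these compounds, so the identity of the group and its position cannot be told apart, and a 2-chlorophenyl or a 3-hydroxyphenyl would bear directly on this. From the compounds shown here alone, how an unsubstituted phenyl, or a methoxy group or an amine on the ring, would compare stays open.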